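The source may hold more compounds than are shown below. What is called first, only, known or untested is meant among the compounds shown, and "the series" means these compounds.

Values in a functional assay for inhibition, with Homo sapiens as the target; on this read-out lower numbers stand for tighter binding and higher numbers for weaker binding:
- compound 1 `CC(C)(Oc1ccc(F)cc1)C1OCC(C/C=C\CCC(=O)O)C(c2cccnc2)O1`: 120 nM
- compound 2 `CC(C)(Cc1ccccc1)C1OCC(C/C=C\CCC(=O)O)C(c2cccnc2)O1`: 513 nM
- compound 3 `CC(C)(Cc1ccc(F)cc1)C1OCC(C/C=C\CCC(=O)O)C(c2cccnc2)O1`: 89.1 nM

Compound 3 and compound 1 share the low end of the set, and the series shows a 1.3-fold lower number from compound 1 to compound 3 (0.13 log units; within the scatter), so the two are not separated. Compound 2 stands apart from both, with a 4.3-fold higher number from compound 1 to compound 2 (0.63 log units; beyond the scatter) and a 5.8-fold lower number from compound 2 to compound 3 (0.76 log units; beyond the scatter).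

The next compound to read is compound 4 `CC(C)(Cc1ccc(F)cc1C#N)C1OCC(C/C=C\CCC(=O)O)C(c2cccnc2)O1`. It differs from compound 3 by one change: cyano in place of hydrogen on an aromatic carbon. In words, this is cyano in place of hydrogen on an aromatic carbon, turning 4-fluorophenyl into 2-cyano-4-fluorophenyl.

Going by the values given here, no measured step contains a cyano group, so the evidence is indirect. Among the compounds with values here, the closest precedent is the other replacement of an aromatic hydrogen, which gave a 5.8-fold lower number from compound 2 to compound 3 (0.76 log units; beyond the scatter). That step shows that a single substituent on this aromatic ring can shift the read-out by a modest amount, but it gives no firm direction for a different group at a different place.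

The estimated change is a 1.5-fold lower number from compound 3 to compound 4 (0.17 log units; within the scatter), so no step beyond the scatter is expected in this assay, with only a slight lean towards a lower number. A modest step either way remains possible. For compound 4 the expected value is 60 nM, with an estimated range from 15 nM to 240 nM.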

Compound 4, dissociation constant: 2.19 nM
Beside the measured number, compound 4's estimate is 27-fold (1.44 log units) above it, and the stated range ends above it.
By their numbers in this assay, from the lowest: compound 4; then compounds 3 and 1 (each within the scatter of the next); then compound 2.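

Working notes: in this assay the aromatic carbon ortho to a large group and meta to a fluoro group turns out to be far more responsive than the earlier compounds indicated, with cyano in place of hydrogen giving a large step (a 41-fold lower number from compound 3 to compound 4 (1.61 log units; beyond the scatter)) where fluoro in place of hydrogen on the same ring gave only a modest one (a 5.8-fold lower number from compound 2 to compound 3 (0.76 log units; beyond the scatter)). With both substituents present, 2-cyano-4-fluorophenyl in place of phenyl gives a large step (a 230-fold lower number from compound 2 to compound 4 (2.37 log units; beyond the scatter)), and the change also separates this compound from the 4-fluorophenoxy compound (a 55-fold lower number from compound 1 to compound 4 (1.74 log units; beyond the scatter)), a separation that the 4-fluorobenzyl compound did not reach within the scatter (a 1.3-fold lower number from compound 1 to compound 3 (0.13 log units; within the scatter)). The data shown offer no measurement that explains the size of the cyano step.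

Open, as far as these compounds go, is whether the step belongs to the nitrile itself or would also appear with another group on the same carbon, such as chloro, methoxy or a primary amide. Also open, from the compounds shown here alone, is whether it needs the fluoro group, as in a 2-cyanophenyl compound, and whether cyano on the 4-fluorophenoxy ring of compound 1 would give a step of similar size.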